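The source may report more compounds than this note shows. Statements on the series, on what has been measured and on what is new or still open speak of the compounds shown alone.

Among the compounds with values here, in a functional assay on PC-3 cells (Homo sapiens) for cytotoxicity, read by MTT assay (on this read-out higher numbers stand for weaker inhibition and lower numbers for stronger inhibition), compound 1 `COc1ccc2cc([C@H](C)c3nnc(SCc4ccc(F)cc4)n3-c3ccc(Cl)cc3)ccc2c1` gives 10800 nM, the lowest of the three numbers measured so far. Compound 2 `COc1ccc(CSc2nnc([C@@H](C)c3ccc4cc(OC)ccc4c3)n2-c2ccc(F)cc2)cc1` gives 400000 nM and compound 3 `COc1cccc(CSc2nnc([C@@H](C)c3ccc4cc(OC)ccc4c3)n2-c2ccc(F)cc2)c1` gives 211000 nM, both higher than the number for compound 1 by well beyond the scatter.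

Compound 4 `COc1ccc2cc([C@H](C)c3nnc(SCc4c(Cl)cccc4Cl)n3-c3ccc(Cl)cc3)ccc2c1` keeps the rest of compound 1 and changes one group: 2,6-dichlorophenyl in place of 4-fluorophenyl on a saturated chain carbon bound to a sulfur. On a saturated chain carbon bound to a sulfur, 2,6-dichlorophenyl stands in place of 4-fluorophenyl.

Within the data shown here, only one measured step touches this place: a 1.9-fold lower number from compound 2 to compound 3 (0.28 log units; within the scatter), with 3-methoxyphenyl in place of 4-methoxyphenyl. Among the measured compounds shown here, it stays within the scatter, and no measured compound carries 2,6-dichlorophenyl there, so the guidance is thin. For the measured compounds named here, with only that step to go on, no change beyond the scatter is expected, at most a slight drift toward a higher number.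

The estimated change is a 1.4-fold higher number from compound 1 to compound 4 (0.14 log units; within the scatter). For compound 4 the expected value is 15000 nM, with an estimated range from 3500 nM to 70000 nM.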

Compound 4, half-maximal inhibitory concentration: 34700 nM
Compound 4: the middle estimate sits 2.3-fold (0.36 log units) below what was measured; low and high end bracket the measured number.
By their numbers in this assay, from the lowest: compound 1; then compound 4; then compounds 3 and 2 (each within the scatter of the next).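

In this assay, within the data shown here, the change on the saturated chain carbon bound to a sulfur gives a 3.2-fold higher number from compound 1 to compound 4 (0.51 log units; beyond the scatter) and so lies beyond the scatter, unlike the one earlier step at this place, which swapped one methoxyphenyl for another. This position therefore does respond to the group it carries, and of the two groups compared on the core of compound 1, 4-fluorophenyl gives the lower number, which stands for stronger inhibition. No evidence shown here accounts for this rise.

Swapping 4-fluorophenyl for 2,6-dichlorophenyl removes the fluorine and adds both chlorines in one step, so the compounds shown cannot tell which part of the change matters. As far as these compounds go, how a plain phenyl ring, or a ring carrying an amine or a carboxylic acid, would read at this place also remains open.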